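Methoxy for methyl on the core of compound 1

The compounds below may be only part of what the source reports. "The series", "measured", "known", "first", "only" and "open" are said of these compounds alone.

Of the compounds shown here, three have been measured in a functional assay on HeLa cells (Homo sapiens) for antiproliferative activity, read by MTT assay, with a stated time of 48 h; on this read-out lower numbers stand for stronger inhibition and higher numbers for weaker inhibition. Compound 1 `Cc1ccc2nc(Nc3ccnc(Nc4ccc(S(C)(=O)=O)cc4)n3)sc2c1` gives 2300 nM in this assay. Compound 2 `CS(=O)(=O)c1ccc(Nc2ncc(F)c(Nc3nc4ccccc4s3)n2)cc1` gives 3170 nM in this assay, a number within the scatter of that of compound 1, so no order between the two can be claimed. Compound 3 `Cc1cnc(Nc2ccc([N+](=O)[O-])cc2)nc1Nc1nc2ccccc2s1` gives 34300 nM in this assay, a number beyond the scatter from compound 1 and the highest of the three. Compound 1 thus stands at the lowest of the three numbers, but only its gap to compound 3 is beyond the scatter.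

Compound 4 `COc1ccc2nc(Nc3ccnc(Nc4ccc(S(C)(=O)=O)cc4)n3)sc2c1` has not yet been measured. It differs from compound 1 in one place: methoxy in place of methyl on an aromatic carbon. The entering methoxy brings one heavy atom more and one hydrogen-bond acceptor where the methyl had none; no ring, donor or charge changes. For the measured compounds named here, no measured pair shows a change of this kind, so the size of the step cannot be read from the data. The expectation is a step of no more than the scatter, in either direction, from compound 1 to compound 4, namely a 1.1-fold higher number from compound 1 to compound 4 (0.04 log units; within the scatter). Compound 4 is therefore estimated at 2500 nM in this assay, with a range from 1000 nM to 6500 nM.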

Compound 4, half-maximal inhibitory concentration: 4130 nM
For compound 4 the middle estimate is 1.7-fold (0.22 log units) below the measured one, and the stated range covers the measured number.
By their numbers in this assay, from the lowest: compounds 1, 2 and 4 (each within the scatter of the next); then compound 3.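

In this assay, for the compounds shown here, compounds 1 and 4 form the first measured pair that differs in one place, and methoxy in place of methyl on an aromatic carbon gives a 1.8-fold higher number from compound 1 to compound 4 (0.25 log units; within the scatter) as the step across it. At this position, on the six-membered aromatic ring of carbon only, the change adds one heavy atom and one hydrogen-bond acceptor, yet the step stays within the scatter, so this read-out does not separate the two compounds. No measurement offered here bears on what lies behind this result.

Still open, as far as these compounds go, is whether a different group at this position, such as an amine, a carboxylic acid or a longer chain like ethoxy, would give a step beyond the scatter in this assay. Also open, from the compounds shown here alone, is whether methoxy in place of methyl would give a step of similar size elsewhere on the shared core, since this single pair speaks for one position only.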